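Methylpiperazine for methyl on a slowly cleared core

The source may hold more compounds than are shown below. What is called first, only, known or untested is meant among the compounds shown, and "the series" means these compounds.

Measured so far in an in vitro ADME assay on microsomes from liver (Homo sapiens) for metabolic stability; on this read-out higher numbers stand for fast clearance and lower numbers for slow clearance:
Compound 1 `Cc1ccc(Cn2c(=O)[nH]c3c(N)nc(-c4ncco4)cc32)cn1` gives < 7 mL.min-1.g-1.
Compound 2 `Cc1ccc(Cn2c(=O)[nH]c3c(N)nc(C(F)(F)F)cc32)cn1` gives < 7 mL.min-1.g-1.
Compound 3 `Cc1ccc(Cn2c(=O)[nH]c3c(N)nc(C(F)(F)F)cc32)nn1` gives < 8 mL.min-1.g-1.

Each of these three values is a limit of the assay rather than a number. Compound 2 thus stands at the limit, as do compound 1 and compound 3, and no order among them can be read. The step that the two limits leave unreadable from compound 1 to compound 2 and the step that the two limits leave unreadable from compound 2 to compound 3 are both unreadable because the values sit at the limit of < 7 mL.min-1.g-1 in this assay, at which 2 of the 3 values shown sit, and (the limit of < 8 mL.min-1.g-1 in this assay, at which 1 of the 3 values shown sits).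

Compound 4 `CN1CCN(c2ccc(Cn3c(=O)[nH]c4c(N)nc(C(F)(F)F)cc43)cn2)CC1` differs from compound 2 by 4-methylpiperazin-1-yl in place of methyl on an aromatic carbon. Neither measured step offers a readable size, so no direction beyond the scatter can be taken from them. Compound 4 is expected to remain close to the limit, with an at least 1.2-fold higher number from compound 2 to compound 4 (0.10 log units; that floor lies within the scatter). Compound 4 is estimated at 9 mL.min-1.g-1, within 4 mL.min-1.g-1 to 22 mL.min-1.g-1.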

Compound 4, intrinsic clearance in microsomes: 30 mL.min-1.g-1
Compound 4: the middle estimate sits 3.3-fold (0.52 log units) below what was measured; measured number outside the range, above it.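

In this assay, 4-methylpiperazin-1-yl on the aromatic carbon next to the ring nitrogen gives the only readable step among the compounds shown: an at least 4.2-fold higher number from compound 2 to compound 4 (0.63 log units; beyond the scatter). This position can therefore move the read-out off the limit, which the earlier changes elsewhere on the molecule could not show. The size of the step remains a floor, because compound 2 stands at a limit: the limit of < 7 mL.min-1.g-1 in this assay, at which 2 of the 4 values shown sit.

As far as these compounds go, it remains open whether morpholin-4-yl or a dimethylamino group at this position would give a similar rise, or whether the value would stay at the limit.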